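The source may hold more compounds than are shown below. What is called first, only, known or untested is meant among the compounds shown, and "the series" means these compounds.

Compound 1 `Cc1cc(-c2cncnc2)cc(C)c1Nc1ccnc(Nc2ccc(C#N)cc2)n1` gives 6800 nM
Compound 2 `Cc1cc(-c2ccc3cc[nH]c3c2)cc(C)c1Nc1ccnc(Nc2ccc(C#N)cc2)n1` gives 5800 nM
Compound 3 `Cc1cc(-c2ccnc(C(F)(F)F)c2)cc(C)c1Nc1ccnc(Nc2ccc(C#N)cc2)n1` gives 6100 nM

In a toxicity assay on MT4 cells (Homo sapiens) for cytotoxicity, read by MTT assay, with a stated time of 5 days (on this read-out lower numbers stand for higher toxicity in this test and higher numbers for lower toxicity in this test), compound 3 gives 6100 nM and stands level with the other two, as all three values lie within the usual scatter of one another. Compound 4 `COc1ncc(-c2cc(C)c(Nc3ccnc(Nc4ccc(C#N)cc4)n3)c(C)c2)cn1` has not been measured yet and differs from compound 3 at one place (2-methoxypyrimidin-5-yl in place of 2-(trifluoromethyl)pyridin-4-yl on an aromatic carbon) with the rest unchanged. Three exchanges at this same place are known: a 1.2-fold lower number from compound 1 to compound 2 (0.07 log units; within the scatter) and a 1.1-fold lower number from compound 1 to compound 3 (0.05 log units; within the scatter) and a 1.1-fold higher number from compound 2 to compound 3 (0.02 log units; within the scatter) are each within the scatter. Expected here is a 1.1-fold higher number from compound 3 to compound 4 (0.03 log units; within the scatter) and so no step beyond the scatter. The estimated value for compound 4 is 6500 nM and the expected range runs from 3500 nM up to 15000 nM for this measurement.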

Compound 4, half-maximal cytotoxic concentration: 4800 nM
For compound 4 the middle estimate is 1.4-fold (0.13 log units) above the measured one; the range from low to high includes it.
By their numbers in this assay, from the lowest: compounds 4, 2, 3 and 1 (each within the scatter of the next).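

In this assay, 2-methoxypyrimidin-5-yl behaves like the groups already tried at this place, with all of these steps within the scatter (a 1.3-fold lower number from compound 3 to compound 4 (0.10 log units; within the scatter); a 1.2-fold lower number from compound 2 to compound 4 (0.08 log units; within the scatter)). This pair also adds something new: it tests a small addition to one ring, and methoxy in place of hydrogen on the pyrimidin-5-yl group stays within the scatter too (a 1.4-fold lower number from compound 1 to compound 4 (0.15 log units; within the scatter)). No supporting data explain why these groups give such similar numbers. From the compounds shown here alone, whether an amine or a carboxylic acid on this ring would move the number beyond the scatter remains open.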